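Sulfonamide series: acetamido for cyano on a second core

This account rests on a few compounds, and the source may have more. Where it says the series, first, only, none or still open, it means among the compounds named here.

Compound 1 `N#Cc1ccc(S(=O)(=O)N2C/C(=C\c3cccnc3)C(=O)/C(=C/c3ccccc3C(F)(F)F)C2)cc1` gives 5060 nM in a functional assay on HepG2 cells (Homo sapiens) for cytotoxicity, read by MTT assay, with a stated time of 24 h; on this read-out higher numbers stand for weaker inhibition and lower numbers for stronger inhibition. Compound 2 `CC(=O)Nc1ccc(S(=O)(=O)N2C/C(=C\c3cccnc3)C(=O)/C(=C/c3ccccc3C(F)(F)F)C2)cc1` carries the change acetamido in place of cyano on an aromatic carbon and in this assay compound 2 gives 4330 nM; the step is a 1.2-fold lower number from compound 1 to compound 2 (0.07 log units; within the scatter). Compound 3 `N#Cc1ccc(S(=O)(=O)N2C/C(=C\c3ccncc3)C(=O)/C(=C/c3ccccc3C(F)(F)F)C2)cc1` differs from compound 1 in its core by pyridin-4-yl in place of pyridin-3-yl on a double-bonded chain carbon bound to a double-bonded ring carbon; in this assay compound 3 gives 5920 nM, a step of a 1.2-fold higher number from compound 1 to compound 3 (0.07 log units; within the scatter). All three numbers sit within the scatter of one another, so no order among them is claimed.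

Compound 4 `CC(=O)Nc1ccc(S(=O)(=O)N2C/C(=C\c3ccncc3)C(=O)/C(=C/c3ccccc3C(F)(F)F)C2)cc1` is not yet measured. It stands to compound 3 as compound 2 stands to compound 1: the change is acetamido in place of cyano on an aromatic carbon, and its place reads the same, word for word, as the place of the change from compound 1 to compound 2, so it counts as the same change carried onto the other core. For the measured compounds named here, only one such step is measured, a 1.2-fold lower number from compound 1 to compound 2 (0.07 log units; within the scatter), and it is within the scatter. The expectation for compound 4 rests on that single step applied to compound 3 and its value 5920 nM. Compound 4 is expected to give 5100 nM in this assay, with 3000 nM and 8500 nM as the expected ends. The expected step of a 1.2-fold lower number from compound 3 to compound 4 (0.06 log units; within the scatter) is within the scatter.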

Compound 4, half-maximal inhibitory concentration: 4840 nM
For compound 4 the middle estimate is 1.1-fold (0.02 log units) above the measured one; measured number inside the range.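

In this assay, acetamido in place of cyano gives a 1.2-fold lower number from compound 3 to compound 4 (0.09 log units; within the scatter), and this step matches the one on the core of compound 1: the same change on two cores in this assay, a 1.2-fold lower number (0.07 log units; within the scatter) from compound 1 to compound 2 and a 1.2-fold lower number (0.09 log units; within the scatter) from compound 3 to compound 4, 1.0-fold (0.02 log units) apart, within the scatter of two such steps

Pyridin-4-yl in place of pyridin-3-yl gives a 1.1-fold higher number from compound 2 to compound 4 (0.05 log units; within the scatter), and this step likewise matches its counterpart on the cyano side: the same change on two cores in this assay, a 1.2-fold higher number (0.07 log units; within the scatter) from compound 1 to compound 3 and a 1.1-fold higher number (0.05 log units; within the scatter) from compound 2 to compound 4, 1.0-fold (0.02 log units) apart, within the scatter of two such steps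

Both changes therefore carry from one core to the other without a readable difference, but every step involved is within the scatter, so this agreement does not show that a step large enough to read would carry over in the same way.

The compounds shown leave open whether an amine or a carboxylic acid in place of cyano or acetamido would give a step beyond the scatter in this assay. Also open, on these data alone, is whether pyridin-2-yl in place of the other pyridine attachments would do so, and whether any such step would hold on both cores.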